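This account rests on a few compounds, and the source may have more. Where it says the series, first, only, none or still open, it means among the compounds named here.

Compound 1 `COc1cc2c(Oc3ccc(NC(=O)c4nn(-c5ccccc5F)cc(C)c4=O)cc3F)ccnc2cc1OCCCC(=O)NO`: 1370 nM
Compound 2 `COc1cc2c(Oc3ccc(NC(=O)c4nn(-c5ccccc5F)cc(C)c4=O)cc3)ccnc2cc1OCCCC(=O)NO`: 3920 nM

For the measured compounds named here, in a functional assay on A549 cells (Homo sapiens) for inhibition, read by MTT assay, with a stated time of 72 h (a lower number here means a stronger inhibitor, a higher number a weaker inhibitor), compound 1 gives 1370 nM, the lower of the two numbers so far, and compound 2 gives 3920 nM.

Compound 3 `COc1cc2c(Oc3ccc(NC(=O)c4nn(-c5ccccc5F)cc(C)c4=O)cc3F)ccnc2cc1OCCCCCC(=O)NO` has not yet been measured. It differs from compound 1 only in the chain: 2-(hydroxycarbamoyl)ethyl in place of hydroxycarbamoyl on a saturated chain carbon, three bonds along the chain from an oxygen on an aromatic ring. Read another way, a 3-(hydroxycarbamoyl)propyl becomes a 5-(hydroxycarbamoyl)pentyl, while the core of compound 1 stays as it is.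

Going by the values given here, the only measured step is a 2.9-fold higher number from compound 1 to compound 2 (0.46 log units; beyond the scatter), with hydrogen in place of fluoro on an aromatic carbon. That step leaves the chain untouched, so the data hold no direct evidence on chain length and give no direction. It serves only as a yardstick of how far one small change has moved the number. A step of about that size, up or down, is therefore the expectation in this assay, with the middle kept close to compound 1.

For compound 3 the estimated value is 1100 nM, with an expected range from 400 nM to 3000 nM. The expected change is a 1.2-fold lower number from compound 1 to compound 3 (0.10 log units; within the scatter).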

Compound 3, half-maximal inhibitory concentration: 1320 nM
Beside the measured number, compound 3's estimate is 1.2-fold (0.08 log units) below it, and the stated range covers the measured number.
By their numbers in this assay, from the lowest: compounds 3 and 1 (each within the scatter of the next); then compound 2.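

Lengthening the 3-(hydroxycarbamoyl)propyl to a 5-(hydroxycarbamoyl)pentyl on the shared core gives, in this assay, a 1.0-fold lower number from compound 1 to compound 3 (0.02 log units; within the scatter), so these two chain lengths cannot be told apart in this cell test. For the compounds shown here, this is the first information on the chain, and it shows that the number can stay in place when the chain grows, whereas the one earlier change, hydrogen in place of fluoro on an aromatic carbon, gave a 2.9-fold higher number from compound 1 to compound 2 (0.46 log units; beyond the scatter). Nothing measured here offers an explanation for this flat result.

As far as these compounds go, two chain lengths make only a very short series, so it remains open whether a shorter (hydroxycarbamoyl)methyl or a chain longer than the 5-(hydroxycarbamoyl)pentyl would also leave the number in place. From the compounds shown here alone, it is equally open whether the hydroxycarbamoyl group itself matters, which a carboxylic acid or an amine in its place on the same chain would test, and whether hydrogen in place of fluoro would have the same effect on the longer chain.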